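Swapping the Basic Tail of a Potent Acylguanidine

This account rests on a few compounds, and the source may have more. Where it says the series, first, only, none or still open, it means among the compounds named here.

The series shares an acylguanidine core carrying a basic chain and a benzyl-type or phenethyl-type arm. Among the measured compounds shown here, in an assay for binding affinity to Melanocortin receptor 4 (Homo sapiens) (on this read-out higher numbers stand for weaker inhibition and lower numbers for stronger inhibition), compound 1 `CCN(CC)CCCC(C)/N=C(/N)NC(=O)c1cccc(F)c1OCc1cc(Br)ccc1OC` gives 900 nM and compound 3 `CCN(CC)CCCC(C)/N=C(/N)NC(=O)c1cccc(F)c1CCc1ccccc1Cl` gives 26000 nM; the single recorded step between them, a 29-fold higher number from compound 1 to compound 3 (1.46 log units; beyond the scatter), shows how strongly the arm on the aromatic carbon moves the number. Compound 2 `COc1ccc(Br)cc1CCc1c(F)cccc1C(=O)/N=C(\N)NCCCCN1CCCCC1` gives 0.58 nM in this assay, the lowest of the three values, well beyond the scatter from both of the others.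

Compound 4 `COc1ccc(Br)cc1CCc1c(F)cccc1C(=O)/N=C(\N)NCCCN1CCN(C)CC1` is compared with compound 2. The change is 4-methylpiperazin-1-yl in place of (piperidin-1-yl)methyl on a saturated chain carbon, three bonds along the chain from an amine nitrogen. For the measured compounds named here, no measured step alters the basic tail alone: the one step recorded concerns the arm, not the chain, so it bears on this change only in showing that the core tolerates large shifts without losing the acylguanidine motif. The arm of compound 2 is kept in compound 4, and the tail change swaps a ring of similar size for one with one more hetero atom while the chain shortens by one.

In the absence of a direct precedent, the step expected from compound 2 to compound 4 is a 3.4-fold higher number from compound 2 to compound 4 (0.54 log units; beyond the scatter), a modest weakening at most. Compound 4 is therefore estimated at 2 nM, within 0.4 nM to 10 nM.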

Compound 4, inhibition constant: 64 nM
Compound 4: middle estimate off by 32-fold (1.51 log units), on the low side, outside the stated range (above it).
By their numbers in this assay, from the lowest: compound 2; then compound 4; then compound 1; then compound 3.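

With the arm of compound 2 held fixed, the step of a 110-fold higher number from compound 2 to compound 4 (2.04 log units; beyond the scatter) in this assay shows that the tail alone can move this read-out by a large amount, beyond the scatter, whereas the earlier step of a 29-fold higher number from compound 1 to compound 3 (1.46 log units; beyond the scatter) had shown this only for a change in the arm. The large step arises even though the group that leaves and the group that enters are equal in heavy-atom count, so the heavy-atom count of this group does not by itself keep the number in place, and replacing 4-(piperidin-1-yl)butyl with 3-(4-methylpiperazin-1-yl)propyl is not a neutral exchange on this arm. Nothing available here explains the size of the step.

The compounds shown leave unseparated the contributions of the ring, with its second hetero atom, and of the chain, as butyl gives way to propyl within the same change. A 3-(piperidin-1-yl)propyl or 4-(4-methylpiperazin-1-yl)butyl tail on the same arm would separate these two contributions, while a morpholine ring would test the ring further.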